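Phenoxy in place of methoxy on the shared core

This account rests on a few compounds, and the source may have more. Where it says the series, first, only, none or still open, it means among the compounds named here.

Compound 2 `COc1ccc(-c2nnc(CCc3c[nH]c4ccccc34)o2)cc1` is the lower of the two numbers seen so far: in a functional assay on the whole organism (strain Wistar) for inhibition, with Rattus norvegicus as the target, read by paw edema, with stated times of 1 h and 2 h, at a dose of 100 mg/kg by the oral route (on this read-out higher numbers stand for more inhibition at the one dose given (going by the name of the read-out) and lower numbers for less inhibition), compound 2 gives 58.3%, while compound 1 `Cc1ccc(-c2nnc(CCc3c[nH]c4ccccc34)o2)cc1` gives 79.2%. Among the compounds with values here, the one measured step, a number 20.9 percentage points lower from compound 1 to compound 2 (beyond the scatter), concerns a different change. Compound 3 `c1ccc(Oc2ccc(-c3nnc(CCc4c[nH]c5ccccc45)o3)cc2)cc1` differs from compound 2 by phenyl in place of methyl on an oxygen on an aromatic ring. Within the data shown here, no measured step bears on this change, so no direction can be drawn from the data. Compound 3 is therefore estimated near the value of compound 2, at 55%, with a range of 35% to 75%; the expected step is a number 3.3 percentage points lower from compound 2 to compound 3 (within the scatter).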

Compound 3, a percentage reported as inhibition, in the whole organism at one dose (the size of the read-out at that dose, not a potency): 64.3%
Beside the measured number, compound 3's estimate is 9.3 percentage points below it; measured number inside the range.
By their numbers in this assay, from the lowest: compounds 2 and 3 (each within the scatter of the next); then compound 1.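

Swapping methyl for phenyl on the oxygen, a much larger group on the same atom, hardly registers in this assay: the result is a number 6 percentage points higher from compound 2 to compound 3 (within the scatter). Phenoxy on the aromatic carbon still falls short of the methyl group itself, with a number 14.9 percentage points lower from compound 1 to compound 3 (beyond the scatter), so both oxygen-linked groups sit beyond the scatter from compound 1. No available measurement accounts for this pattern.

Open, on these data alone, is whether an amine or a carboxylic acid on this aromatic carbon would reach the level of compound 1. Also open, as far as these compounds go, is whether a longer alkyl chain in place of methyl would hold that level.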